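Three Aryl Variants, Three Limits, One Open Question

The source may hold more compounds than are shown below. What is called first, only, known or untested is meant among the compounds shown, and "the series" means these compounds.

In a functional assay on A549 cells (Homo sapiens) for inhibition, read by MTT assay, with a stated time of 24 h (a lower number here means a stronger inhibitor, a higher number a weaker inhibitor), compound 3 `CCOC(=O)C1=Cc2ccccc2OC1(OCc1cc(-c2ccc3ccccc3c2)no1)C(F)(F)F` reaches only a limit of the assay, > 150000 nM. Compound 1 `CCOC(=O)C1=Cc2ccccc2OC1(OCc1cc(-c2ccc(F)cc2F)no1)C(F)(F)F` likewise stops at a limit, > 150000 nM. Compound 2 `CCOC(=O)C1=Cc2ccccc2OC1(OCc1cc(-c2ccc(C)cc2)no1)C(F)(F)F` also reports a limit rather than a number, > 150000 nM. Because every value sits at the limit of > 150000 nM in this assay, at which 3 of the 3 values shown sit, none of the three steps among them can be sized: a step that the two limits leave unreadable from compound 1 to compound 2, a step that the two limits leave unreadable from compound 1 to compound 3 and a step that the two limits leave unreadable from compound 2 to compound 3 are all unreadable.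

Compound 4 `CCOC(=O)C1=Cc2ccccc2OC1(OCc1cc(-c2ccc(OC)cc2)no1)C(F)(F)F` is the next member of the series. Its change from compound 3 is 4-methoxyphenyl in place of naphthalen-2-yl on an aromatic carbon. Every measured step touches the same position on this five-membered ring, and none of them gives a readable size or direction, so there is no basis for expecting a move in this assay beyond the scatter, and the most likely outcome is another limit. Compound 4 is therefore expected to give about 250000 nM in this assay, within a range of 100000 nM to 1000000 nM. The expected step is a step that the limit leaves unreadable from compound 3 to compound 4.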

Compound 4, half-maximal inhibitory concentration: > 150000 nM
Compound 4: a limit, no number (the forecaster's own chance of this, stated with the estimate: 85%); the middle value lies beyond the limit too.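

In this assay compound 4 gives > 150000 nM, a limit and not a number, so no step joining it to compound 1, compound 2 or compound 3 can be read: the limit of > 150000 nM in this assay, at which 4 of the 4 values shown sit.

The compounds shown leave open whether any group at this place can give a measurable inhibition.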